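The compounds below may be only part of what the source reports. "The series", "measured", "known", "first", "only" and "open" are said of these compounds alone.

The study gathers three close relatives built on a shared core. Compound 1 `Cc1ccc(C(=O)Nc2ccc(CNC(=O)OCc3cccnc3)cc2)c(N2CCCC2)c1` carries a methyl group and a pyrrolidin-1-yl group on that core, while compound 2 `O=C(NCc1ccc(NC(=O)c2cc(Cl)ccc2N2CCCC2)cc1)OCc1cccnc1` carries a chloro group together with the pyrrolidin-1-yl group. In a functional assay on SGC-7901 cells (Homo sapiens) for inhibition, read by MTT assay, with a stated time of 72 h (a higher number here means a weaker inhibitor, a lower number a stronger inhibitor), compound 1 gives 75200 nM. Compound 2 stands at the limit of > 100000 nM in this assay, at which 1 of the 2 values shown sits. In this assay compound 2 gives only a limit, > 100000 nM, and no number is known for it.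

Compound 3 `Cc1ccc(N2CCCC2)c(C(=O)Nc2ccc(CNC(=O)OCc3cccnc3)cc2)c1` has not yet been measured. Set against compound 2, it differs by methyl in place of chloro on an aromatic carbon. Within the data shown here, no step between two measured compounds is available, so the size of the change can only be anticipated: one heavy atom is exchanged for one heavy atom, with no ring and no donor or acceptor added or lost, and in this assay no step beyond the usual scatter is expected in either direction.

Compound 3 is therefore expected to give about 90000 nM in this assay, within a range from 40000 nM to 200000 nM. The estimated step of an at least 1.1-fold lower number from compound 2 to compound 3 (0.04 log units; that floor lies within the scatter) is expected to be small, if any.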

Compound 3, half-maximal inhibitory concentration: 65300 nM
For compound 3 the middle estimate is 1.4-fold (0.14 log units) above the measured one, and the stated range covers the measured number.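

In this assay, among these compounds, the exchange of chloro for methyl on an aromatic carbon, para to a pyrrolidin-1-yl group, can now be read for the first time, and it gives an at least 1.5-fold lower number from compound 2 to compound 3 (0.18 log units; that floor lies within the scatter). With methyl at this position, compound 3 gives a number, 65300 nM. The step, however, is only a floor that lies within the scatter, so the data do not establish that this exchange moves the read-out, and they do not exclude a larger step. The reading stays one-sided, since compound 2 has only a limit of the assay and not a number: the limit of > 100000 nM in this assay, at which 1 of the 3 values shown sits.

Going by these compounds, the true size of the step from chloro to methyl remains open, and so does the question of whether this position tolerates anything beyond these two small groups. An amine, a carboxylic acid or a longer chain such as propyl at the same aromatic carbon could show whether the read-out responds to this position at all, or whether the numbers stay as weak as those seen here.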